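This account rests on a few compounds, and the source may have more. Where it says the series, first, only, none or still open, it means among the compounds named here.

Among the measured compounds shown here, compound 3, `COc1ccc(C(=O)/C=C/c2cc(-c3cc(OC)c(OC)c(OC)c3)n[nH]2)cc1OC`, is one of three compounds measured in a functional assay on ACHN cells (Homo sapiens) for cytotoxicity, read by sulforhodamine B assay, with a stated time of 48 h, tested at 10 uM; on this read-out lower numbers stand for a stronger effect and higher numbers for a weaker effect at the one concentration tested. In this assay compound 3 gives -95%. Compound 2, `COc1ccc(-c2cc(/C=C/C(=O)c3cc(OC)c(OC)c(OC)c3)[nH]n2)cc1OC`, gives -95%, level with compound 3 at the digits shown, so together they stand lowest. For the measured compounds named here, compound 1, `COc1cc(-c2cc(/C=C/C(=O)c3ccc(Cl)c(Cl)c3)[nH]n2)cc(OC)c1OC`, gives 67%, the highest of the three; the single measured step, a number 162 percentage points lower from compound 1 to compound 3 (beyond the scatter), is large and lies beyond the scatter. Compound 4, `COc1cc(C(=O)/C=C/c2cc(-c3cc(OC)c(OC)c(OC)c3)n[nH]2)cc(OC)c1OC`, differs from compound 3 by methoxy in place of hydrogen on an aromatic carbon. Going by the values given here, the one measured step also concerns the aryl on the carbonyl carbon, but it exchanged the whole substitution pattern, whereas here only one methoxy enters. Compound 4 is therefore expected to stay close to compound 3, with a number 10 percentage points higher from compound 3 to compound 4 (within the scatter) not beyond the scatter, and its estimated value is -85%, in the range -105% to -55%.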

Compound 4, a percentage reported as activity, at one concentration (the size of the read-out at that concentration, not a potency): -97%
For compound 4 the middle estimate is 12 percentage points above the measured one, and the stated range covers the measured number.
By their numbers in this assay, from the lowest: compounds 4, 2 and 3 (each within the scatter of the next); then compound 1.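

In this assay, methoxy in place of hydrogen on the aryl at the carbonyl carbon gives a number 2 percentage points lower from compound 3 to compound 4 (within the scatter), so this place accepts the extra methoxy while the strong effect seen with compound 3 is kept. The same change on the other aryl gives a number 2 percentage points lower from compound 2 to compound 4 (within the scatter), which extends this reading to both aryl groups. Nothing measured here explains this result. Going by these compounds, whether an amine or a carboxylic acid would be accepted at this place remains open. Any difference among compounds 2, 3 and 4 also remains unresolved at the one concentration tested.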